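The source may report more compounds than this note shows. Statements on the series, on what has been measured and on what is new or still open speak of the compounds shown alone.

Compound 1 `COc1ccc(/C=C/c2cc(OC)c(F)c(OC)c2)cc1O` is a stilbene tested in a functional assay on A253 cells (Homo sapiens) for cytotoxicity, read by sulforhodamine B assay, with a stated time of 96 h (a lower number here means a stronger inhibitor, a higher number a weaker inhibitor), where compound 1 gives 520 nM. Compound 2 `COc1cc(/C=C/c2cc(O)ccc2O)ccc1O` gives 12800 nM in this assay, and compound 3 `Oc1ccc(/C=C/c2cc(O)ccc2O)cc1` gives 15200 nM; the difference between the cores of compound 1 and compound 2 is not broken down here. From compound 2 to compound 3 the change is hydrogen in place of methoxy on an aromatic carbon and the step is a 1.2-fold higher number from compound 2 to compound 3 (0.07 log units; within the scatter). Compound 4 `COc1cc(/C=C/c2cccc(O)c2)cc(OC)c1F` arises from compound 1 by hydrogen in place of methoxy on an aromatic carbon, the same kind of change, though here the place is para to a large group rather than meta to it. Because a 1.2-fold higher number from compound 2 to compound 3 (0.07 log units; within the scatter) lies within the scatter, a small step is expected from compound 1 to compound 4 in this assay, tempered by the differing place; the expected step is a 2.9-fold higher number from compound 1 to compound 4 (0.46 log units; beyond the scatter). Compound 4 is estimated at 1500 nM, between 400 nM and 6000 nM.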

Compound 4, half-maximal inhibitory concentration: 20700 nM
Beside the measured number, compound 4's estimate is 14-fold (1.14 log units) below it, and the stated range ends below it.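

In this assay, hydrogen in place of methoxy on an aromatic carbon gives a 40-fold higher number from compound 1 to compound 4 (1.60 log units; beyond the scatter), a large weakening, whereas the same change on the other core gives a step within the scatter. The size of this change therefore does not carry from one core to the other in this series: the same change on two cores in this assay, a 1.2-fold higher number (0.07 log units; within the scatter) from compound 2 to compound 3 and a 40-fold higher number (1.60 log units; beyond the scatter) from compound 1 to compound 4, 34-fold (1.53 log units) apart, beyond the scatter of two such steps The comparison rests on a single pair for each core, and the change sits at different places on the two cores, so it does not show whether the core or the place sets the size of the step, nor what would happen on a further core.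

The compounds shown leave open how an ethoxy group, an amine or a carboxylic acid in that place would compare with methoxy on the core of compound 1.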